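Methyl in place of hydrogen on the chain from compound 3 to compound 4

This account rests on a few compounds, and the source may have more. Where it says the series, first, only, none or still open, it means among the compounds named here.

Compound 1: `CC/N=C(/NC#N)NCCCn1nc(-c2ccccc2)ccc1=O`, 62.9%
Compound 2: `C/N=C(/NC#N)NCCCCn1nc(-c2ccccc2)c(C)cc1=O`, 46.4%
Compound 3: `C/N=C(/NC#N)NCCCn1nc(-c2ccccc2)c(C)cc1=O`, 17.2%

In a functional assay on the whole organism with Rattus norvegicus as the target, at a dose of 100 mg/kg (on this read-out lower numbers stand for less inhibition and higher numbers for more inhibition at the one dose given (going by the name of the read-out)), compound 3 gives 17.2%, the lowest of the three numbers; compound 2 stands nearest, compound 1 furthest, and both gaps lie beyond the scatter. Among the compounds with values here, the one step measured in one place, a number 29.2 percentage points lower from compound 2 to compound 3 (beyond the scatter), concerns the length of the chain, not the group on the saturated chain carbon bound to a double-bonded nitrogen, so it does not bear directly on the change to compound 4.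

Compound 4, `CC/N=C(/NC#N)NCCCn1nc(-c2ccccc2)c(C)cc1=O`, differs from compound 3 by methyl in place of hydrogen on a saturated chain carbon bound to a double-bonded nitrogen. Compound 1 carries the ethyl too, and in this assay compound 1 gives 62.9%, but it differs from compound 3 in a second place as well, so that pair is not a clean guide. Within the data shown here, with no measured step in this place, compound 4 is expected to show at most a small rise, a number 12.8 percentage points higher from compound 3 to compound 4 (beyond the scatter), and its estimated value is 30%, within the range 10% to 55%.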

Compound 4, a percentage reported as inhibition, in the whole organism at one dose (the size of the read-out at that dose, not a potency): 0.2%
Compound 4: middle estimate off by 29.8 percentage points, on the high side; the measured number lies below the stated range.
By their numbers in this assay, from the lowest: compound 4; then compound 3; then compound 2; then compound 1.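

In this assay, methyl in place of hydrogen on a saturated chain carbon bound to a double-bonded nitrogen gives a number 17 percentage points lower from compound 3 to compound 4 (beyond the scatter), so the first step read at this place runs downward, and methyl to ethyl there brings no gain with the rest of compound 3 held. With the ethyl kept, methyl in place of hydrogen on an aromatic carbon gives a number 62.7 percentage points lower from compound 1 to compound 4 (beyond the scatter), which shows that the high number of compound 1 does not carry over to compound 4. The change in the group on the chain gives a number 46.2 percentage points lower from compound 2 to compound 4 (beyond the scatter), placing compound 4 lowest of the four.

The compounds shown leave open whether propyl at this place would lower the number further, and whether the same methyl to ethyl step falls when the aromatic methyl is replaced by hydrogen. They offer no evidence on the cause of these falls.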